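Triazole series: cytotoxicity notes ahead of compound 4

The source may hold more compounds than are shown below. What is called first, only, known or untested is meant among the compounds shown, and "the series" means these compounds.

compound 1 `CCC[C@H](CCn1cncn1)c1ccccc1` 63.1 ug/mL
compound 2 `CCC[C@H](CCn1cncn1)c1ccc(OC)cc1` 59.3 ug/mL
compound 3 `c1ccc(C[C@@H](CCn2cncn2)c2ccccc2)cc1` 56 ug/mL

In an ADME assay on RD cells (Homo sapiens) for cytotoxicity, read by MTT assay, with a stated time of 3 days (a higher number here means that more compound is tolerated, a lower number that less compound is tolerated), the three measured compounds sit close together; all three values lie within the scatter of one another, so no order among them is claimed. Compound 2 differs from compound 1 by one change, (methoxy in place of hydrogen on an aromatic carbon), and this gave a 1.1-fold lower number from compound 1 to compound 2 (0.03 log units; within the scatter). Compound 4 `COc1ccc([C@H](CCn2cncn2)Cc2ccccc2)cc1` is not yet measured; it differs from compound 3 by methoxy in place of hydrogen on an aromatic carbon, the same change as from compound 1 to compound 2. The difference between the two cores, that of compound 1 and that of compound 3, is not broken down here. The step from compound 3 to compound 4 is expected to be a 1.0-fold lower number from compound 3 to compound 4 (0.02 log units; within the scatter), essentially flat, because a 1.1-fold lower number from compound 1 to compound 2 (0.03 log units; within the scatter) was within the scatter. Compound 4 is therefore estimated at 54 ug/mL, with a likely range from 30 ug/mL to 95 ug/mL.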

Compound 4, half-maximal cytotoxic concentration: 66 ug/mL
Beside the measured number, compound 4's estimate is 1.2-fold (0.09 log units) below it; the range from low to high includes it.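

In this assay, methoxy in place of hydrogen on an aromatic carbon gives a 1.2-fold higher number from compound 3 to compound 4 (0.07 log units; within the scatter), so on the core of compound 3 this change has no readable effect. Set beside the earlier step, the two cores show no difference for this change: the same change on two cores in this assay, a 1.1-fold lower number (0.03 log units; within the scatter) from compound 1 to compound 2 and a 1.2-fold higher number (0.07 log units; within the scatter) from compound 3 to compound 4, 1.3-fold (0.10 log units) apart, within the scatter of two such steps. This supports carrying the change between these two cores only; it assigns no direction to the change and says nothing about any other core.

Still open, as far as these compounds go, is whether a different group at this place, such as an amine or a carboxylic acid, would give a step beyond the scatter. Also open, from the compounds shown here alone, is whether a longer chain on the shared core would do so.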